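Swapping a hydroxypropyl chain for an ethylsulfonyl group

The compounds below may be only part of what the source reports. "The series", "measured", "known", "first", "only" and "open" are said of these compounds alone.

Measured in an ADME assay on MT4 cells (Homo sapiens) for cytotoxicity, read by MTT assay, with a stated time of 5 days (on this read-out lower numbers stand for higher toxicity in this test and higher numbers for lower toxicity in this test), so far:
compound 1 `CCC(C)N(c1ccnc(Nc2ccc(C#N)cc2)n1)c1c(F)cc(-c2ccc(C#N)cc2)cc1F` gives 217000 nM;
compound 2 `N#Cc1ccc(Nc2nccc(N(CCCO)c3c(F)cc(-c4ccc(C#N)cc4)cc3F)n2)cc1` gives 68000 nM;
compound 3 `N#Cc1ccc(Nc2nccc(N(CCCF)c3c(F)cc(-c4ccc(C#N)cc4)cc3F)n2)cc1` gives 241000 nM.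

Compound 2 has the lowest of the three numbers, so it is the most toxic of the set in this assay: the others stand apart from it by a 3.2-fold lower number from compound 1 to compound 2 (0.50 log units; beyond the scatter) and by a 3.5-fold higher number from compound 2 to compound 3 (0.55 log units; beyond the scatter), both beyond the scatter. Compound 4 `CCS(=O)(=O)N(c1ccnc(Nc2ccc(C#N)cc2)n1)c1c(F)cc(-c2ccc(C#N)cc2)cc1F` differs from compound 2 in one place: ethylsulfonyl in place of 3-hydroxypropyl on a nitrogen on an aromatic ring. The step from compound 2 to compound 3 bears on this, since it also removes the hydroxy and gave a modest rise, while a 1.1-fold higher number from compound 1 to compound 3 (0.05 log units; within the scatter) shows the chain tail hardly matters otherwise. Among the measured compounds shown here, no measured step involves a sulfonyl, so the expectation is loose. Compound 4 is expected near 150000 nM, between 50000 nM and 400000 nM, an expected step of a 2.2-fold higher number from compound 2 to compound 4 (0.34 log units; beyond the scatter).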

Compound 4, half-maximal cytotoxic concentration: > 125000 nM
Compound 4: only a limit was reported; the forecaster's own chance of this, stated with the estimate: 20%; the middle value is on the limit's open side.
By their numbers in this assay, from the lowest: compound 2; then compounds 1 and 3 (each within the scatter of the next).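

Compound 4 in this assay gives > 125000 nM as a limit and not a number. Among the compounds shown here, the one readable step is an at least 1.8-fold higher number from compound 2 to compound 4 (0.26 log units; that floor lies within the scatter) and so ethylsulfonyl on this nitrogen, with no hydroxy left, shows no sign of a lower number, though a real rise is not established. The steps linking compound 4 to compounds 1 and 3 cannot be read. Where the true number of compound 4 lies stays open, as does how a methylsulfonyl group or a chain ending in an amine would read on this nitrogen.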